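The source may hold more compounds than are shown below. What is called first, only, known or untested is meant among the compounds shown, and "the series" means these compounds.

Measured compounds:
compound 1, `Oc1ccccc1CNc1ccc(-c2cccc(Cl)c2)cc1`: 6200 nM
compound 2, `Cc1cccc(-c2ccc(NCc3ccccc3O)cc2)c1`: 9190 nM
compound 3, `Oc1ccccc1CNc1ccc(-c2ccccc2Cl)cc1`: "not active" (no number reported)

In a functional assay on Jurkat cells (Homo sapiens) for activation, with a stated time of 24 h (a higher number here means that more compound is needed for the effect, a lower number that less compound is needed), compound 1 gives 6200 nM. Compound 2 carries methyl in place of chloro on an aromatic carbon, and in this assay compound 2 gives 9190 nM; the step of a 1.5-fold higher number from compound 1 to compound 2 (0.17 log units; within the scatter) is within the scatter, so the two values cannot be told apart. Compound 3 differs from compound 1 by 2-chlorophenyl in place of 3-chlorophenyl on an aromatic carbon. In this assay compound 3 is reported as "not active" (no number reported), and no number was given for it.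

Compound 4, `Cc1ccccc1-c1ccc(NCc2ccccc2O)cc1`, has not yet been measured. It stands to compound 3 as compound 2 stands to compound 1: the change is methyl in place of chloro on an aromatic carbon. The two changes are the same kind of change, not the same. The place differs: in compound 1 to compound 2 the exchanged group sits meta to a large group, whereas in compound 3 to compound 4 it sits ortho to a large group.

Among the measured compounds shown here, the one measured instance of this kind of change, a 1.5-fold higher number from compound 1 to compound 2 (0.17 log units; within the scatter), is within the scatter. If the same holds at the other place, compound 4 is expected to stay close to compound 3, which gave no number. Compound 4 is therefore estimated at 30000 nM in this assay, with a range from 8000 nM to 100000 nM, and it is expected that the assay may again report only a limit rather than a number.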

Compound 4, half-maximal effective concentration: 5220 nM
For compound 4 the middle estimate is 5.7-fold (0.76 log units) above the measured one; the whole stated range lies above it.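

In this assay compound 3 is reported as not active with no number, while compound 4 gives 5220 nM, so the step between them cannot be read as a size; the same kind of change on the other core gave a 1.5-fold higher number from compound 1 to compound 2 (0.17 log units; within the scatter). The numbers that can be compared put compound 4 with the other two, with a 1.8-fold lower number from compound 2 to compound 4 (0.25 log units; within the scatter) and a 1.2-fold lower number from compound 1 to compound 4 (0.07 log units; within the scatter), which leaves compound 3, with its 2-chlorophenyl group, as the only one of the four without a number. This shows that exchanging chloro for methyl does not carry the same outcome from one core to the other, since it leaves the values within the scatter in one case and separates a compound with no number from one with a number in the other, but it does not show how large the second change is, and nothing given here bears on why the two cases part.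

What a methoxy, an amine or a carboxylic acid would do at this place, ortho to a large group, stays open among the compounds shown. Also open, on these data alone, is whether a longer chain such as ethyl at that place would stand with compound 4 or with compound 3.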